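The source may report more compounds than this note shows. Statements on the series, on what has been measured and on what is new or still open speak of the compounds shown alone.

In a functional assay on MCF7 cells (Homo sapiens) for cytotoxicity, read by MTT assay, with a stated time of 96 h (on this read-out higher numbers stand for weaker inhibition and lower numbers for stronger inhibition), compound 1 `Cc1cc2c(c(=O)o1)C(c1ccco1)C(C#N)=C(N)O2` gives 27000 nM. Among the three measured numbers this is the second highest: compound 3 `Cc1cc2c(c(=O)o1)C(c1ccc([N+](=O)[O-])cc1)C(C#N)=C(N)O2` gives 42000 nM, and the two lie within the scatter of each other, while compound 2 `Cc1cc2c(c(=O)o1)C(c1ccc(Cl)s1)C(C#N)=C(N)O2` gives 12000 nM, a gap beyond the scatter. Within the data shown here, the only measured step of a single change, a 2.3-fold lower number from compound 1 to compound 2 (0.35 log units; beyond the scatter), swaps the aryl group on the saturated ring carbon and yields a modest shift. Compound 4 `Cc1ccc(C2C(C#N)=C(N)Oc3cc(C)oc(=O)c32)cc1` differs from compound 1 in that same place: 4-methylphenyl in place of furan-2-yl on a saturated ring carbon. That one precedent points to, at most, a modest move, and compound 3 shows a different aryl group sitting within the scatter of compound 1. The step of a 1.4-fold lower number from compound 1 to compound 4 (0.13 log units; within the scatter) is therefore expected to be small. Compound 4 is estimated to give 20000 nM, with a likely range from 8000 nM to 50000 nM.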

Compound 4, half-maximal inhibitory concentration: 54000 nM
Beside the measured number, compound 4's estimate is 2.7-fold (0.43 log units) below it, outside the stated range (above it).
By their numbers in this assay, from the lowest: compound 2; then compounds 1, 3 and 4 (each within the scatter of the next).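

On the saturated ring carbon, 4-methylphenyl and 5-chlorothiophen-2-yl can be told apart, with a 4.5-fold higher number from compound 2 to compound 4 (0.65 log units; beyond the scatter) clearing the scatter. By contrast, a 2.0-fold higher number from compound 1 to compound 4 (0.30 log units; within the scatter) and a 1.3-fold higher number from compound 3 to compound 4 (0.11 log units; within the scatter) both stay within it, so compounds 1, 3 and 4 cannot be separated by these numbers. No measured evidence here accounts for these results. Still open, on these data alone, is whether the chlorine or the thiophene ring sets compound 2 apart, and whether a carboxylic acid or an aminomethyl group on the phenyl ring would shift the number.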